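Ester to Acid Repeated on a Second Core

The source may hold more compounds than are shown below. What is called first, only, known or untested is meant among the compounds shown, and "the series" means these compounds.

Compound 2 `C=C(CCCC)C(=O)c1ccc(OCC(=O)OC)c(C)c1C` and compound 1 `C=C(CCCC)C(=O)c1ccc(OCC(=O)O)c(C)c1C` share one core and differ in a single spot: hydrogen in place of methyl on an oxygen next to a carbonyl group. In a functional assay on HL-60 cells (Homo sapiens) for antiproliferative activity, with a stated time of 72 h (a higher number here means a weaker inhibitor of growth, a lower number a stronger inhibitor of growth), compound 2 gives 8600 nM, while compound 1 gives 14400 nM, a step of a 1.7-fold higher number from compound 2 to compound 1 (0.22 log units; within the scatter). Compound 3 `C=C(CCC)C(=O)c1ccc(OC(C)C(=O)OC)c(C)c1C` has the same atoms as compound 2 joined differently; the difference between the two cores is not broken down here. In this assay compound 3 gives 5600 nM. Compound 4 `C=C(CCC)C(=O)c1ccc(OC(C)C(=O)O)c(C)c1C` has not yet been measured in this assay. It differs from compound 3 by hydrogen in place of methyl on an oxygen next to a carbonyl group, the same change at the same place as seen between compound 2 and compound 1. Because the earlier change gave a 1.7-fold higher number from compound 2 to compound 1 (0.22 log units; within the scatter), a step of similar size is expected, a 1.7-fold higher number from compound 3 to compound 4 (0.23 log units; within the scatter). Compound 4 is therefore estimated to give 9500 nM in this assay, with a likely range from 4000 nM to 22000 nM.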

Compound 4, concentration for 50% growth inhibition: 11200 nM
Estimate against measurement, compound 4: 1.2-fold (0.07 log units) below; measured number inside the range.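

In this assay, replacing methoxycarbonyl with carboxy on the second core gives a 2.0-fold higher number from compound 3 to compound 4 (0.30 log units; within the scatter). Set beside the first case, the two steps match: the same change on two cores in this assay, a 1.7-fold higher number (0.22 log units; within the scatter) from compound 2 to compound 1 and a 2.0-fold higher number (0.30 log units; within the scatter) from compound 3 to compound 4, 1.2-fold (0.08 log units) apart, within the scatter of two such steps This shows that the change behaves alike on these two cores, but each step lies within the scatter, so neither one alone separates an acid from its methyl ester, and two cores cannot establish a rule for the whole series.

The compounds shown leave open how an ethyl ester or an amide would compare with the methoxycarbonyl and carboxy groups. From the compounds shown here alone, whether the same step appears on cores beyond these two also remains unknown.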